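Adding a Naphthalene Ring to an Ester Tail

The compounds below may be only part of what the source reports. "The series", "measured", "known", "first", "only" and "open" are said of these compounds alone.

Compound 1 `CC(C)N(Cc1cccc(OCCCCCC(=O)O)c1)C(=O)c1ccccc1` in an ADME assay on HepG2 cells (Homo sapiens) for cytotoxicity, read by CellTiter-Glo and resazurin assay, with a stated time of 72 h (a higher number here means that more compound is needed for the effect, a lower number that less compound is needed), gives > 26000 nM, which is a limit of the assay.
Compound 2 `CC(C)N(Cc1cccc(OCCCCCC(=O)O)c1)C(=O)c1ccc(-c2ccc3[nH]ccc3c2)cc1` in this assay gives > 26000 nM, also a limit of the assay.
Compound 3 `CCOC(=O)CCCCCOc1cccc(CN(C(=O)c2ccccc2)C(C)C)c1` in this assay gives > 26000 nM, again a limit of the assay.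

None of these values is a number: every measurement so far sits at the limit of > 26000 nM in this assay, at which 3 of the 3 values shown sit. Compound 3 therefore stands at the limit, with no readable number to set beside the others. The entry of 1H-indol-5-yl reads a step that the two limits leave unreadable from compound 1 to compound 2, and the ethyl on the oxygen next to a carbonyl group reads a step that the two limits leave unreadable from compound 1 to compound 3. Compound 4 `CCOC(=O)CCCCCOc1cccc(CN(C(=O)c2ccc(-c3ccc4ccccc4c3)cc2)C(C)C)c1` carries naphthalen-2-yl in place of hydrogen on an aromatic carbon. Both measured steps start and end at the limit, so neither can show how large the effect of a new aromatic ring is. The nearest comparison is the entry of 1H-indol-5-yl, which left compound 2 at the limit. For compound 4 the expected step is a step that the limit leaves unreadable from compound 3 to compound 4, with the result most likely reported once more as a limit. Compound 4 is estimated at 30000 nM, within 10000 nM to 100000 nM.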

Compound 4, half-maximal effective concentration: > 26000 nM
Compound 4: no number, only a limit (the forecaster's own chance of this, stated with the estimate: 75%); the middle value is on the limit's open side.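

Compound 4 gives > 26000 nM, which is again a limit of the assay and not a number, so no step from compound 3 can be read: the limit of > 26000 nM in this assay, at which 4 of the 4 values shown sit.

The compounds shown leave open what concentration of any of them produces the effect in this assay, and whether naphthalen-2-yl changes it at all.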